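Chloro in place of methyl on a fused carboxamide core

The compounds below may be only part of what the source reports. "The series", "measured", "known", "first", "only" and "open" are said of these compounds alone.

Compound 1 `CNc1ncc(C(N)=O)c(C)n1` gives > 10000 nM in an assay on isolated protein for inhibition of Nicotinamide N-methyltransferase (Homo sapiens), read by luminescence, with a stated time of 20 min (a higher number here means a weaker inhibitor, a lower number a stronger inhibitor), which is a limit of the assay and not a number.
Compound 2 `NC(=O)c1cnc2c(c1)CCN2` gives 175 nM in this assay.
Compound 3 `Cc1c(C(N)=O)cnc2c1CCN2` gives 102 nM in this assay.

Of the two numbers shown, compound 3 holds the lower one, and its nearest neighbour is compound 2. The step between them, a 1.7-fold lower number from compound 2 to compound 3 (0.23 log units; within the scatter), lies within the scatter, so no order between compound 2 and compound 3 can be read from it. Compound 1 sits at the limit of > 10000 nM in this assay, at which 1 of the 3 values shown sits, and its value says only that much.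

Compound 4 `NC(=O)c1cnc2c(c1Cl)CCN2` differs from compound 3 by chloro in place of methyl on an aromatic carbon. Within the data shown here, no measured step exchanges a methyl for a chloro; the only measured step on this core is a 1.7-fold lower number from compound 2 to compound 3 (0.23 log units; within the scatter), which placed a methyl where a hydrogen had been and stayed within the scatter. Nothing in the measured compounds points to a large move in either direction for this exchange, so a step beyond the scatter is not expected in this assay. On that basis compound 4 is estimated at 100 nM, with a likely range from 35 nM to 300 nM. The expected step is therefore a 1.0-fold lower number from compound 3 to compound 4 (0.01 log units; within the scatter), with the true value to be settled by measurement.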

Compound 4, half-maximal inhibitory concentration: 92 nM
Beside the measured number, compound 4's estimate is 1.1-fold (0.04 log units) above it; the range from low to high includes it.
By their numbers in this assay, from the lowest: compounds 4, 3 and 2 (each within the scatter of the next). At a limit, above all of these: compound 1.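

At this place on the shared core, ortho to the carbamoyl group and opposite the ring nitrogen, the exchange of methyl for chloro gives a 1.1-fold lower number from compound 3 to compound 4 (0.04 log units; within the scatter) in this assay and so sets no order between the two groups. Measured against the unsubstituted compound, chloro gives a 1.9-fold lower number from compound 2 to compound 4 (0.28 log units; within the scatter) and thus also stays within the scatter, so that hydrogen, methyl and chloro at this one position now form a set of three whose members cannot be told apart in this assay, where before only hydrogen and methyl had been compared. Nothing measured here on any property of these groups bears on this result.

The compounds shown leave open whether a methoxy group, an amine or a longer chain at this same place would stay within the scatter of these three or would move the number beyond it. They also leave open what a carboxylic acid or a nitrile in place of the carbamoyl group would give on this core.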